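The source may hold more compounds than are shown below. What is called first, only, known or untested is meant among the compounds shown, and "the series" means these compounds.

Two compounds share the core of compound 1 `CCOc1cc(NC(=O)C2(NC(=O)c3ccc4c(C5CCCC5)c(-c5ncc(Cl)cn5)n(C)c4c3)CCC2)ccc1/C=C/C(=O)OCC(C)C` and have been run in an ADME assay (liver) for pharmacokinetics, with Liver microsome (Homo sapiens) as the target, using microsomes; on this read-out higher numbers stand for a longer-lived compound and lower numbers for a shorter-lived compound. Compound 1 reaches the limit of this assay, > 5 h. Compound 2 `CCOc1cc(NC(=O)C2(NC(=O)c3ccc4c(C5CCCC5)c(-c5ncc(Cl)cn5)n(C)c4c3)CCC2)ccc1/C=C/C(=O)OCC(=O)OC` gives 2.1 h, the only plain number shown. Between them, an at least 2.3-fold lower number from compound 1 to compound 2 (0.37 log units; beyond the scatter), a change at the ester end of the chain. Compound 3 `CCOc1cc(NC(=O)C2(NC(=O)c3ccc4c(C5CCCC5)c(-c5ncc(Cl)cn5)n(C)c4c3)CCC2)ccc1/C=C/C(=O)OCC(N)=O` changes that same end differently: amino in place of methoxy on a carbonyl carbon. Among the compounds with values here, the one measured step concerns another group, so it gives no clear direction for this change. Compound 3 is therefore expected near compound 2, with a 1.4-fold higher number from compound 2 to compound 3 (0.15 log units; within the scatter), estimated at 3 h within 1.2 h to 6 h.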

Compound 3, half-life: 0.983 h
Estimate against measurement, compound 3: 3.1-fold (0.48 log units) above; measured number outside the range, below it.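

In this assay, the ester end of the chain responds even to a small exchange on its carbonyl carbon, with amino in place of methoxy: a 2.1-fold lower number from compound 2 to compound 3 (0.33 log units; beyond the scatter). Measured against the isobutyl-type end of the first compound, the carbamoyl end gives an at least 5.0-fold lower number from compound 1 to compound 3 (0.70 log units; beyond the scatter). Compound 1 stands at a limit, not at a plain number: the limit of > 5 h in this assay, at which 1 of the 3 values shown sits.

The compounds shown leave open how a carboxylic acid or a longer chain at this end would read. They also leave open whether a methylamino group on that carbonyl carbon would fall closer to compound 2 or compound 3.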